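The source may hold more compounds than are shown below. What is called first, only, known or untested is meant among the compounds shown, and "the series" means these compounds.

Working notes on the series. Going by the values given here, compound 2 `CN1C(=O)C2(C(C#N)=C(N)Oc3cc4oc(-c5ccccc5)cc(=O)c4c(O)c32)c2cc(Br)ccc21` is the only member with a numbered result in a functional assay on NCI-H1299 cells (Homo sapiens) for antiproliferative activity, read by MTT assay, with a stated time of 48 h; on this read-out higher numbers stand for weaker inhibition and lower numbers for stronger inhibition: compound 2 gives 7610 nM. Compound 1 `CN1C(=O)C2(C(C#N)=C(N)Oc3cc4oc(-c5ccccc5)cc(=O)c4c(O)c32)c2ccccc21` reaches only a limit of the assay in this assay, > 50000 nM. Compound 3 `Cc1cccc2c1N(Cc1ccccc1)C(=O)C21C(C#N)=C(N)Oc2cc3oc(-c4ccccc4)cc(=O)c3c(O)c21` likewise reaches only a limit in this assay, > 50000 nM. Among the compounds with values here, the one measured step, an at least 6.5-fold lower number from compound 1 to compound 2 (0.81 log units; beyond the scatter), is the bromo entering on an aromatic carbon; its size is bounded by the limit of > 50000 nM in this assay, at which 2 of the 3 values shown sit. Compound 4 `N#CC1=C(N)Oc2cc3oc(-c4ccccc4)cc(=O)c3c(O)c2C12C(=O)N(Cc1ccccc1)c1ccc(Br)cc12` is compound 2 with the change (phenyl in place of hydrogen on a saturated chain carbon bound to an amide-type nitrogen in a ring). Within the data shown here, no measured step covers this change: compound 3 carries a benzyl on the amide-type nitrogen but also a methyl on an aromatic carbon and no bromo, and compound 1 and compound 3 both give no numbered value, so the pair shows nothing about benzyl against methyl on its own. The bromo is kept in compound 4, so the step of an at least 6.5-fold lower number from compound 1 to compound 2 (0.81 log units; beyond the scatter) still counts in its favour. With no evidence for or against the benzyl, the step expected for compound 4 is a 1.3-fold higher number from compound 2 to compound 4 (0.12 log units; within the scatter), none beyond the scatter, with a wide range. Compound 4 is therefore expected at 10000 nM, between 3000 nM and 50000 nM.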

Compound 4, half-maximal inhibitory concentration: > 50000 nM
Compound 4: no number, only a limit (the forecaster's own chance of this, stated with the estimate: 30%); middle value at least 5.0-fold (0.69 log units) away from the limit.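

In this assay the change from methyl to benzyl, with the bromo kept, gives an at least 6.5-fold higher number from compound 2 to compound 4 (0.81 log units; beyond the scatter) and so removes the numbered activity seen for compound 2. The bromo alone therefore does not secure a numbered result, and in this one matched pair the amide-type nitrogen in a ring carries methyl with a measurable result where benzyl gives none. Compound 4 gives only a limit of the assay, > 50000 nM, so the step has a bound and not a full size, and the same limit now dominates the series: the limit of > 50000 nM in this assay, at which 3 of the 4 values shown sit.

As far as these compounds go, whether the loss belongs to the phenyl itself or to any growth beyond methyl on that nitrogen stays open, and an ethyl, a propyl or a cyclohexylmethyl at this place would separate the two readings. Also open, from the compounds shown here alone, is whether the numbered result of compound 2 depends on bromo specifically, which a chloro or a methoxy on the same aromatic carbon would test with the methyl kept on the nitrogen.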